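Swapping Aminomethyl for Bromo on a Shared Core

The source may report more compounds than this note shows. Statements on the series, on what has been measured and on what is new or still open speak of the compounds shown alone.

Of the compounds shown here, three have so far been measured in an ADME assay on HEp-2 cells (Homo sapiens) for cytotoxicity; on this read-out lower numbers stand for higher toxicity in this test and higher numbers for lower toxicity in this test. Compound 1 `CC(C)CCn1c(Cn2c(=O)n(C(C)C)c3ccccc32)nc2cc(CN)ccc21` gives 3920 nM, the lowest of the three numbers. Compound 3 `CNCc1ccc2nc(Cn3c(=O)n(C(C)C)c4ccccc43)n(CCC(C)C)c2c1` gives 4810 nM, which lies within the scatter of compound 1, so the two cannot be told apart. Compound 2 `CC(C)CCn1c(Cn2c(=O)n(CC(=O)OC(C)(C)C)c3ccccc32)nc2cc(/C(N)=N\O)ccc21` gives 19800 nM, a number beyond the scatter of compound 1 and therefore less toxic in this test. Compound 4 `CC(C)CCn1c(Cn2c(=O)n(C(C)C)c3ccccc32)nc2cc(Br)ccc21` is not yet measured; it differs from compound 1 by bromo in place of aminomethyl on an aromatic carbon. For the measured compounds named here, no measured pair shows this change, so its effect in this assay is unknown. A step within the scatter, if anything leaning toward lower numbers, is expected, amounting to an estimated 1.3-fold lower number from compound 1 to compound 4 (0.12 log units; within the scatter). Compound 4 is accordingly estimated at 3000 nM, with a range from 1200 nM to 8000 nM.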

Compound 4, half-maximal cytotoxic concentration: 18100 nM
Compound 4: middle estimate off by 6.0-fold (0.78 log units), on the low side; the whole stated range lies below it.
By their numbers in this assay, from the lowest: compounds 1 and 3 (each within the scatter of the next); then compounds 4 and 2 (each within the scatter of the next).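

In this assay, for the compounds shown here, putting bromo in place of aminomethyl on this aromatic carbon gives a 4.6-fold higher number from compound 1 to compound 4 (0.66 log units; beyond the scatter), showing for the first time in a single-place comparison that a change here can move the number beyond the scatter. Nothing measured here accounts for this step.

Going by these compounds, it remains open whether the step comes from losing aminomethyl or from gaining bromo. Compounds carrying a chloro, methyl or hydroxymethyl group at this position could help separate those two readings.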